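The source may hold more compounds than are shown below. What is called first, only, known or untested is meant among the compounds shown, and "the series" means these compounds.

In a functional assay on the whole organism (strain Icem-CET (SPF Caw)) for inhibition, with Mus musculus as the target, with a stated time of 30 min (a lower number here means that less compound is needed, a higher number that more compound is needed for the effect), compound 3 `C=CCNC(=O)/C(C)=C(\C)c1ccc(C)cc1` gives 78 mg/kg. Among the three compounds measured so far, compound 3 stands second highest: compound 2 `C#CCNC(=O)/C(C)=C(\C)c1ccc(C)cc1` gives 86.4 mg/kg, and these two numbers lie within the scatter of each other, while compound 1 `C#CCNC(=O)/C(C)=C(\C)c1ccc(Cl)cc1` gives 10.6 mg/kg, the lowest number of the three. Compound 4 `C=CCNC(=O)/C(C)=C(\C)c1ccc(Cl)cc1` has not yet been measured; it differs from compound 3 in one place: chloro in place of methyl on an aromatic carbon. Among the measured compounds shown here, two measured steps bear on this change. The step from compound 1 to compound 2 is the same swap run the other way, methyl replacing chloro on the ring, and it gave an 8.2-fold higher number from compound 1 to compound 2 (0.91 log units; beyond the scatter). The step from compound 2 to compound 3 changed only the chain on the amide nitrogen and gave a 1.1-fold lower number from compound 2 to compound 3 (0.04 log units; within the scatter), so the choice of ethynyl or vinyl chain appears to leave the number where it was, and compound 4 combines the vinyl chain of compound 3 with the chloro of compound 1. Returning to chloro is therefore expected to bring a step of about a 7.8-fold lower number from compound 3 to compound 4 (0.89 log units; beyond the scatter), a clearly lower number, landing close to compound 1. Compound 4 is estimated at 10 mg/kg, with a likely range from 5 mg/kg to 22 mg/kg.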

Compound 4, dose for half-maximal effect: 18.6 mg/kg
For compound 4 the middle estimate is 1.9-fold (0.27 log units) below the measured one, within the range that was stated.
By their numbers in this assay, from the lowest: compounds 1 and 4 (each within the scatter of the next); then compounds 3 and 2 (each within the scatter of the next).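

In this assay the swap of chloro for methyl on the aromatic carbon now has a second reading, on the vinyl chain, where it gives a 4.2-fold lower number from compound 3 to compound 4 (0.62 log units; beyond the scatter) and so shows that the lower number with chloro is not confined to the ethynyl chain of compound 1. Read in the opposite direction, methyl in place of chloro raises the number on both chains, and the two readings agree: the same change on two cores in this assay, an 8.2-fold higher number (0.91 log units; beyond the scatter) from compound 1 to compound 2 and a 4.2-fold higher number (0.62 log units; beyond the scatter) from compound 4 to compound 3, 1.9-fold (0.29 log units) apart, within the scatter of two such steps. The chain change also has a second reading, on the chloro core, where it gives a 1.8-fold higher number from compound 1 to compound 4 (0.24 log units; within the scatter), so vinyl and ethynyl stay within the scatter of each other on both cores, and here too the readings agree: the same change on two cores in this assay, a 1.1-fold lower number (0.04 log units; within the scatter) from compound 2 to compound 3 and a 1.8-fold higher number (0.24 log units; within the scatter) from compound 1 to compound 4, 1.9-fold (0.29 log units) apart, within the scatter of two such steps.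

The compounds shown carry only chloro or methyl at this ring position and only a vinyl or ethynyl chain on the amide nitrogen, so what a fluoro or methoxy group on the ring, or a longer saturated chain on the nitrogen, would do stays open. Two cores also cannot tell why chloro gives the lower number, or whether the pattern holds beyond these four compounds.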